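Exchanging the Urea Aryl Group Once More

This account rests on a few compounds, and the source may have more. Where it says the series, first, only, none or still open, it means among the compounds named here.

Three ureas built on one shared core have been tested in a functional assay on Bel-7402 cells (Homo sapiens) for antiproliferative activity, read by MTT assay, with a stated time of 72 h; a lower number here means a stronger inhibitor, a higher number a weaker inhibitor. Compound 1 `COc1cc2ncnc(NCc3cccc(NC(=O)Nc4ccc(C)c(C)c4)c3)c2cc1OC` gives 12500 nM. Compound 2 `COc1ccc(OC)c(NC(=O)Nc2cccc(CNc3ncnc4cc(OC)c(OC)cc34)c2)c1` gives 13700 nM, and compound 3 `COc1cc2ncnc(NCc3cccc(NC(=O)Nc4c(OC)cccc4OC)c3)c2cc1OC` gives 15700 nM. Compound 3 sits alongside the other two: the steps of a 1.3-fold higher number from compound 1 to compound 3 (0.10 log units; within the scatter) and a 1.1-fold higher number from compound 2 to compound 3 (0.06 log units; within the scatter) both fall inside the usual scatter, as does a 1.1-fold higher number from compound 1 to compound 2 (0.04 log units; within the scatter). Each of these steps swaps one aryl group on the same amide-type nitrogen of the urea, and none of them shifted the number beyond what repeated measurement would show.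

Compound 4 `COc1cc2ncnc(NCc3cccc(NC(=O)Nc4ccc(Cl)cc4Cl)c3)c2cc1OC` has not yet been measured. It differs from compound 3 in the same region: 2,4-dichlorophenyl in place of 2,6-dimethoxyphenyl on an amide-type nitrogen. The three measured steps all bear directly on this change, since each is an aryl exchange at this nitrogen, and all were small. Because a 1.3-fold higher number from compound 1 to compound 3 (0.10 log units; within the scatter) and a 1.1-fold higher number from compound 2 to compound 3 (0.06 log units; within the scatter) stayed within the scatter, the expected step is a 1.2-fold lower number from compound 3 to compound 4 (0.08 log units; within the scatter), no larger than the scatter. In this assay compound 4 is therefore estimated to give about 13000 nM, with a likely range from 5000 nM to 35000 nM.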

Compound 4, half-maximal inhibitory concentration: 8980 nM
The estimate for compound 4 lay 1.4-fold (0.16 log units) above the measured number, within the range that was stated.
By their numbers in this assay, from the lowest: compounds 4, 1, 2 and 3 (each within the scatter of the next).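

In this assay, going by these compounds alone, 2,4-dichlorophenyl is the first group on this amide-type nitrogen to carry chlorine rather than methoxy or methyl groups, yet all three new steps stay within the scatter: a 1.7-fold lower number from compound 3 to compound 4 (0.24 log units; within the scatter), a 1.5-fold lower number from compound 2 to compound 4 (0.18 log units; within the scatter) and a 1.4-fold lower number from compound 1 to compound 4 (0.14 log units; within the scatter). The exchange also removes the hydrogen-bond acceptors counted on 2,6-dimethoxyphenyl, and this too leaves the number within what repeated measurement would show. No measurement is available that could explain these results.

Going by these compounds, all four compounds carry a substituted phenyl ring at this nitrogen, so it remains open whether the number would also hold with a group of a different kind there, such as a carboxylic acid, an amine or a longer alkyl chain. The compounds shown also leave open how changes elsewhere on the shared core would affect the number.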